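This account rests on a few compounds, and the source may have more. Where it says the series, first, only, none or still open, it means among the compounds named here.

In a physicochemical assay for lipophilicity, at pH 7.4 (on this read-out higher numbers stand for higher lipophilicity and lower numbers for lower lipophilicity), three compounds have been measured so far. Compound 1 `CCc1ccc(N(CC(C)C)S(=O)(=O)c2ccc3c(c2)C(O)CC(C2CCOCC2)O3)cc1` gives 4.12, compound 2 `CCc1ccc(N(CC(C)C)S(=O)(=O)c2ccc3c(c2)C(C)CC(C2CCOCC2)O3)cc1` gives 5.71, and compound 3 `O=S(=O)(c1ccc2c(c1)C(O)CC(C1CCOCC1)O2)N1CCCC1c1ccccc1C(F)(F)F` gives 3.41. Compound 2 therefore stands highest of the three, beyond the scatter of both others.

The next compound is compound 4 `CCc1ccc(N(CC(C)C)S(=O)(=O)c2ccc3c(c2)C(N)CC(C2CCOCC2)O3)cc1`, which carries amino in place of methyl on a saturated ring carbon of compound 2: amino in place of methyl on a saturated ring carbon.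

Within the data shown here, one measured step bears on this change. With methyl in place of hydroxy on a saturated ring carbon, the number rises by a number 1.59 log units higher from compound 1 to compound 2 (beyond the scatter), a large step beyond the scatter. Compound 3 differs from compound 2 in more than one place and says little here. Among the measured compounds shown here, no measured compound yet carries amino, so the comparison with hydroxy is only a guide. A large downward step is expected, similar to the measured one or somewhat greater.

The expected change is a number 2.01 log units lower from compound 2 to compound 4 (beyond the scatter). For compound 4 the estimated number is 3.7, with an expected range of 3 to 4.4.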

Compound 4, distribution coefficient: 3.08
The estimate for compound 4 lay 0.62 log units above the measured number, and the stated range covers the measured number.
By their numbers in this assay, from the lowest: compound 4; then compound 3; then compound 1; then compound 2.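

In this assay the saturated ring carbon proves highly sensitive to its substituent, with amino in place of methyl giving a number 2.63 log units lower from compound 2 to compound 4 (beyond the scatter) and so a change larger than the one seen with hydroxy. Among these compounds, the new compound also separates the two heteroatom groups, which the earlier compounds could not do: amino in place of hydroxy gives a number 1.04 log units lower from compound 1 to compound 4 (beyond the scatter) and, across compounds 1, 2 and 4, the order from lowest to highest at this carbon is amino, hydroxy, methyl. Nothing available gives a measured reason for this order.

The compounds shown leave open where a methylamino or dimethylamino group, a methoxy group or a fluorine atom would fall at this carbon. They also leave open whether the same order holds with the different sulfonyl substituent of compound 3, which has only hydroxy here.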